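The source may report more compounds than this note shows. Statements on the series, on what has been measured and on what is new or still open speak of the compounds shown alone.

Measured in a functional assay on NCI-H460 cells (Homo sapiens) for antiproliferative activity, read by MTT assay, with a stated time of 72 h; a higher number here means a weaker inhibitor, a lower number a stronger inhibitor:
- compound 1 `O=c1c(-c2ccc(F)cc2)c[nH]c2ccnc(Nc3ccc(Oc4ccnc5cc(OCCO)ccc45)c(F)c3)c12`: 3500 nM
- compound 2 `O=c1c(-c2ccc(F)cc2)c[nH]c2ccnc(Nc3ccc(Oc4ccnc5cc(O)ccc45)c(F)c3)c12`: 43000 nM

Compound 2, at 43000 nM, stands highest of the two measured compounds, which makes it the weaker inhibitor, and compound 1 is its nearest neighbour. Compound 3 `CC(O)COc1ccc2c(Oc3ccc(Nc4nccc5[nH]cc(-c6ccc(F)cc6)c(=O)c45)cc3F)ccnc2c1` departs from compound 2 in one place: 2-hydroxypropyl in place of hydrogen on an oxygen on an aromatic ring. In words, this is 2-hydroxypropyl in place of hydrogen on an oxygen on an aromatic ring.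

For the measured compounds named here, one measured step bears on this change. It is a 12-fold higher number from compound 1 to compound 2 (1.09 log units; beyond the scatter), a large step seen on replacing 2-hydroxyethyl with hydrogen at that same oxygen. Compound 3 goes the opposite way, restoring a chain of the same kind in the form of 2-hydroxypropyl. A large step towards a lower number is therefore expected in this assay. Going by the values given here, this expectation rests on a single step, and no measured compound carries 2-hydroxypropyl itself, so its size remains uncertain.

The expected change is an 11-fold lower number from compound 2 to compound 3 (1.03 log units; beyond the scatter). For compound 3 the estimated value is 4000 nM, with an expected range of 1500 nM to 11000 nM.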

Compound 3, half-maximal inhibitory concentration: 3400 nM
Compound 3: the middle estimate sits 1.2-fold (0.07 log units) above what was measured, within the range that was stated.
By their numbers in this assay, from the lowest: compounds 3 and 1 (each within the scatter of the next); then compound 2.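

In this assay, the large effect at this oxygen is not confined to 2-hydroxyethyl: 2-hydroxypropyl in place of hydrogen gives a 13-fold lower number from compound 2 to compound 3 (1.10 log units; beyond the scatter). The methyl that separates the two chains, placed on a saturated chain carbon bound to an oxygen on a saturated carbon and a saturated chain carbon, leaves a 1.0-fold lower number from compound 1 to compound 3 (0.01 log units; within the scatter), so this assay does not tell the two chains apart. Among the three compounds, the free hydroxy of compound 2 therefore stands alone at the high end, and neither of the two chains goes against this. Nothing available explains why either chain has this effect.

On these data alone, both chains carry a hydroxy group, so it remains open whether a plain methyl or ethyl on this oxygen would give a number like those of compound 1 and compound 3, or one closer to that of compound 2. Also open, as far as these compounds go, is how far the chain can be varied at this oxygen, whether by a longer chain or by one ending in an amine or a carboxylic acid.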